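The compounds below may be only part of what the source reports. "The series", "measured", "known", "first", "only" and "open" are said of these compounds alone.

Working notes on the series, read-out a physicochemical assay for lipophilicity, at pH 7.4; a lower number here means a more polar compound, a higher number a more lipophilic compound. Compound 1 `Cc1cc(NC(=O)NCCCC[C@@H](Nc2cc(C)c(F)c(C)c2)C(=O)NO)ccc1F` gives < 3, which is a limit and not a number. Compound 2 `Cc1cc(N[C@H](CCCCNCc2cccc(F)c2)C(=O)NO)cc(C)c1F` gives < 3, again only a limit. Compound 3 `CO[C@H](C[C@H](CCN(C)CCCc1ccccc1)C(=O)NO)c1ccc(F)cc1` gives < 3, also only a limit. Taken together, the evidence is the limit of < 3 in this assay, at which 3 of the 3 values shown sit, so compound 3 has no number of its own and no measured step is available for scaling.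

The next compound is compound 4 `CO[C@H](C[C@H](CCN(C)CCCc1ccc(F)c(C)c1)C(=O)NO)c1ccc(F)cc1`. It keeps the core of compound 3 and differs in one place: 4-fluoro-3-methylphenyl in place of phenyl on a saturated chain carbon, three bonds along the chain from an amine nitrogen. Going by the values given here, no measured pair covers this change, so the expectation rests on the structural change alone: a modest move towards the higher end of this assay. Counted from a limit, the expected step is a number at least 0.10 log units higher from compound 3 to compound 4 (that floor lies within the scatter), and the true rise could be larger. For compound 4 the estimate is 3.1, with an expected range of 2.5 to 3.6. A further limit in this assay would be no surprise.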

Compound 4, distribution coefficient: < 3
Compound 4 was reported as a limit (the forecaster's own chance of this, stated with the estimate: 45%); middle value at least 0.10 log units from the limit.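

In this assay compound 4 gives < 3, which is a limit and not a number. Compound 3 also carries only a limit, so no step can be read between compound 3 and compound 4. The compounds shown leave open the actual value of each compound and the size of any shift from phenyl to 4-fluoro-3-methylphenyl, with the series resting on a single limit: the limit of < 3 in this assay, at which 4 of the 4 values shown sit.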